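A few compounds are considered here, and "the series" means these few. Any claim that something is new, unique, unknown or untested is made for them only; others in the source may bear on it.

Compound 1, whose structure is `O=C1O[C@H]([C@@H](O)Cn2cc(CCO)nn2)C(OCc2ccccc2)=C1OCc1ccccc1`, is a weakly active compound in a functional assay on MCF7 cells (Homo sapiens) for antiproliferative activity, read by MTT assay, with a stated time of 72 h (on this read-out higher numbers stand for weaker inhibition and lower numbers for stronger inhibition), where compound 1 gives 63400 nM. Only one other value is shown for comparison. Compound 2, with the structure `CCCCCc1ccc(-c2cn(C/C=C3\OC(=O)C(OCc4ccccc4)=C3OCc3ccccc3)nn2)cc1`, reaches only the limit of this assay, recorded as > 100000 nM; this is a limit of the measurement and not a number, a point summarised as the limit of > 100000 nM in this assay, at which 1 of the 2 values shown sits. Compound 1 therefore holds the only actual number shown, and it sits well toward the weak end.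

Compound 3, whose structure is `CCCCc1cn(C[C@H](O)[C@H]2OC(=O)C(OCc3ccccc3)=C2OCc2ccccc2)nn1`, is to be measured next. It is obtained from compound 1 by the change (ethyl in place of hydroxy on a saturated chain carbon, two bonds along the chain from an aromatic carbon). Within the data shown here, no pair of measured compounds differing in one place is available, so the size of this step cannot be read from any neighbouring example. The expectation is a small step, not clearly beyond the usual scatter, in this assay, with the estimated step of a 1.6-fold lower number from compound 1 to compound 3 (0.20 log units; within the scatter). On that basis compound 3 is expected to give about 40000 nM, with a likely range from 15000 nM to 100000 nM.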

Compound 3, half-maximal inhibitory concentration: 7910 nM
Compound 3: middle estimate off by 5.1-fold (0.70 log units), on the high side; the measured number lies below the stated range.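

In this assay, putting ethyl in place of hydroxy on a saturated chain carbon, two bonds along the chain from an aromatic carbon, gives an 8.0-fold lower number from compound 1 to compound 3 (0.90 log units; beyond the scatter). This shows that this position responds to the change and that the hydroxy is not required there for activity against these cells, since the 4-butyl-1H-1,2,3-triazol-1-yl compound gives the lower number. Nothing measured here gives a reason for the step.

From the compounds shown here alone, what remains open is how much of the step belongs to the loss of the hydroxy and how much to the added carbons, and a propyl group or a methoxy group at this place could help to separate the two. Going by these compounds, it also remains open whether a longer chain such as hexyl would lower the number further, and how an amine or a carboxylic acid would behave at the same place.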